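The source may hold more compounds than are shown below. What is called first, only, known or untested is meant among the compounds shown, and "the series" means these compounds.

Three compounds built on one shared core have been examined in a functional assay (HSMC cells, Homo sapiens) for antiproliferative activity, with a stated time of 72 h; a lower number here means a stronger inhibitor, a higher number a weaker inhibitor. Compound 1, with the structure `COC(=O)[C@H](CCSC)NC(=O)c1ccc(OC[C@H]2COc3ccccc3O2)cc1-c1ccccc1C`, gives 6600 nM. Compound 2, with the structure `COC(=O)CNC(=O)c1ccc(OC[C@H]2COc3ccccc3O2)cc1-c1ccccc1C`, gives 27000 nM, and compound 3, with the structure `COC(=O)CNC(=O)c1ccc(OC[C@H]2COc3ccccc3O2)cc1-c1ccccc1OC`, gives 71000 nM. Among these three numbers compound 2 stands second highest: compound 1 lies a step below it, as a 4.1-fold higher number from compound 1 to compound 2 (0.61 log units; beyond the scatter) shows, and compound 3 a step above it, as a 2.6-fold higher number from compound 2 to compound 3 (0.42 log units; beyond the scatter) shows.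

Compound 4, with the structure `COC(=O)[C@H](CC(C)C)NC(=O)c1ccc(OC[C@H]2COc3ccccc3O2)cc1-c1ccccc1C`, is the next compound to be measured. It differs from compound 2 in one place: isobutyl in place of hydrogen on a saturated chain carbon bound to an amide-type nitrogen and a carbonyl carbon. Among the compounds with values here, of the measured steps, only the one from compound 1 to compound 2 bears on this, since it also concerns a chain on that same carbon; removing 2-(methylsulfanyl)ethyl there gave a 4.1-fold higher number from compound 1 to compound 2 (0.61 log units; beyond the scatter). Putting isobutyl onto that carbon is the reverse kind of change with a chain of comparable length, so a step in this assay of roughly the opposite direction and similar size is expected. Compound 4 is therefore estimated at 8000 nM, with a likely range from 3000 nM to 22000 nM. That estimate means an expected step of a 3.4-fold lower number from compound 2 to compound 4 (0.53 log units; beyond the scatter).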

Compound 4, half-maximal inhibitory concentration: 3000 nM
Beside the measured number, compound 4's estimate is 2.7-fold (0.43 log units) above it, and the stated range covers the measured number.
By their numbers in this assay, from the lowest: compound 4; then compound 1; then compound 2; then compound 3.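

In this assay, the saturated chain carbon bound to an amide-type nitrogen and a carbonyl carbon now has two different chains to set against hydrogen, and isobutyl there gives a 9.0-fold lower number from compound 2 to compound 4 (0.95 log units; beyond the scatter) so the lower number seen with 2-(methylsulfanyl)ethyl is not tied to that one chain. The make-up of the chain also counts and not only its presence, since isopropyl in place of (methylsulfanyl)methyl at the far part of the chain gives a 2.2-fold lower number from compound 1 to compound 4 (0.34 log units; beyond the scatter) which is a smaller step than the one from hydrogen but still beyond the usual scatter. Nothing available here accounts for why either chain lowers the number.

From the compounds shown here alone, how far this trend extends remains open, for example whether a longer chain, a phenyl ring, an amine or a carboxylic acid on that same carbon would lower the number further or raise it again. Going by these compounds, it is also open whether the higher number that came with methoxy in place of methyl on an aromatic carbon would carry over to a compound that has the isobutyl chain.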